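The compounds below may be only part of what the source reports. "The series", "measured", "known", "first", "only" and "open" are said of these compounds alone.

Within the data shown here, in a toxicity assay on MT4 cells (Homo sapiens) for cytotoxicity, read by MTT assay (a higher number here means that more compound is tolerated, a lower number that less compound is tolerated), compound 1 (`Cc1cc(-c2ccc(C#N)c(C#N)c2)ccc1Oc1cc(N)nc(Nc2ccc(C#N)cc2)n1`) gives 76700 nM, the highest of the three numbers measured so far. Compound 2 (`COc1ccccc1-c1cc(C)c(Oc2cc(N)nc(Nc3ccc(C#N)cc3)n2)c(C)c1`) gives 21800 nM and compound 3 (`Cc1cc(-c2ccc(C#N)c(C#N)c2)cc(C)c1Oc1cc(N)nc(Nc2ccc(C#N)cc2)n1`) gives 17600 nM, and these two lie within the scatter of each other. Compound 4 (`Cc1cc(-c2cccc(F)c2)ccc1Oc1cc(N)nc(Nc2ccc(C#N)cc2)n1`) is compound 1 with one change, 3-fluorophenyl in place of 3,4-dicyanophenyl on an aromatic carbon. The closest guide is another swap of one such group for another, 2-methoxyphenyl to 3,4-dicyanophenyl, which gave a 1.2-fold lower number from compound 2 to compound 3 (0.09 log units; within the scatter), within the scatter. The other measured step, a 4.4-fold lower number from compound 1 to compound 3 (0.64 log units; beyond the scatter), is larger, but it belongs to methyl in place of hydrogen on an aromatic carbon, a change that compound 4 does not make. Among the measured compounds shown here, no measured compound carries 3-fluorophenyl, so the guide is indirect, and it comes from compounds that have the extra methyl. No step beyond the scatter is expected in this assay, although compound 1 stands at the top of the measured numbers, so a slightly lower number seems the safer expectation. The expected step is a 1.5-fold lower number from compound 1 to compound 4 (0.19 log units; within the scatter). Compound 4 is estimated at 50000 nM, with an expected range from 17000 nM to 150000 nM.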

Compound 4, half-maximal cytotoxic concentration: 11300 nM
Estimate against measurement, compound 4: 4.4-fold (0.65 log units) above; the whole stated range lies above it.
By their numbers in this assay, from the lowest: compounds 4, 3 and 2 (each within the scatter of the next); then compound 1.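

In this assay the 3-fluorophenyl group in place of 3,4-dicyanophenyl gives a 6.8-fold lower number from compound 1 to compound 4 (0.83 log units; beyond the scatter) and shows that the group on this aromatic carbon can move the tolerated concentration beyond the usual scatter. The earlier swap on the same carbon, 2-methoxyphenyl to 3,4-dicyanophenyl, gave a 1.2-fold lower number from compound 2 to compound 3 (0.09 log units; within the scatter) and hinted at little sensitivity here, but that pair carries an extra methyl group that compound 1 and compound 4 lack, so the two results need not conflict. The change removes two nitriles and brings in one fluorine, but nothing available explains the lower number or ties it to either of these parts.

Going by these compounds, it remains open whether one nitrile on the phenyl ring would be enough to keep a number as high as that of compound 1, or whether a phenyl ring carrying an amine or a carboxylic acid on this carbon would behave more like compound 1 or like compound 4. It is also unknown whether 3-fluorophenyl would give a similar step in the presence of the extra methyl group.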